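Quinoline ketones: tetrazolyl replaces hydroxymethylphenyl at compound 1

The compounds below may be only part of what the source reports. "The series", "measured", "known", "first", "only" and "open" are said of these compounds alone.

Measured so far:
compound 1 `Cc1cc(-c2ccc3ccc(C(=O)c4ccc(F)c(O)c4)nc3c2)ccc1O` — 11%
compound 2 `O=C(c1ccc(F)c(O)c1)c1ccc2ccccc2c1` — 64%
compound 3 `C=C(c1ccc(F)c(O)c1)c1cccc(-c2cccc(O)c2F)n1` — 88%

In an assay for inhibition of 17-beta-hydroxysteroid dehydrogenase type 1 (Homo sapiens), read by HPLC, with a stated time of 10 min, tested at 1 uM (on this read-out lower numbers stand for less inhibition and higher numbers for more inhibition at the one concentration tested (going by the name of the read-out)), compound 1 gives 11%. That is the lowest of the three numbers. The nearest is compound 2, which gives 64% in this assay, a number higher by more than the scatter. The furthest is compound 3, which gives 88%, again higher by more than the scatter. Among the measured compounds shown here, no pair among the measured compounds differs in only one place, so no single step is available to calibrate the move considered here.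

Compound 4 `O=C(c1ccc(F)c(O)c1)c1ccc2ccc(-c3nnn[nH]3)cc2n1` is not yet measured. It is built on the core of compound 1 with one change:

1H-tetrazol-5-yl in place of 4-hydroxy-3-methylphenyl on an aromatic carbon

The 4-hydroxy-3-methylphenyl of compound 1 leaves; 1H-tetrazol-5-yl enters on the same aromatic carbon of the fused two-ring system.

Without a calibrating step, the expectation rests on where compound 1 stands: its number is the lowest shown, and compound 2, which carries no group on the fused core, gives 64%. An upward step is therefore expected, of the size a number 34 percentage points higher from compound 1 to compound 4 (beyond the scatter), beyond the scatter but with wide uncertainty. For compound 4 the estimate in this assay is 45%, expected to fall between 15% and 75%.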

Compound 4, a percentage reported as inhibition, at one concentration (the size of the read-out at that concentration, not a potency) in the 17-beta-hydroxysteroid dehydrogenase type 1 assay: "not active" (no number reported)
Compound 4 has no reported number here; no gap can be computed for the estimate.
By their numbers in the 17-beta-hydroxysteroid dehydrogenase type 1 assay, from the lowest: compound 1; then compound 2; then compound 3.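

Among the compounds shown here, in the 17-beta-hydroxysteroid dehydrogenase type 1 assay compound 4 is reported as "not active" without a number, so no new step from compound 1 to compound 4 can be read there. In a physicochemical assay for solubility, in phosphate buffer, with a stated time of 24 h, at pH 7.4, tested at 200 uM (on this read-out higher numbers stand for higher solubility and lower numbers for lower solubility), compound 1 gives 13000 nM and compound 4 gives 50000 nM, which is a 3.8-fold higher number from compound 1 to compound 4 (0.59 log units; beyond the scatter). The compounds shown leave open how large any inhibition by compound 4 is in the 17-beta-hydroxysteroid dehydrogenase type 1 assay.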